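This account rests on a few compounds, and the source may have more. Where it says the series, first, only, none or still open, it means among the compounds named here.

Three compounds share one core and differ only in the group on an amide-type nitrogen. Compound 1 `O=C(COc1ccc2cc(/C=C3/SC(=O)NC3=O)ccc2c1)Nc1ccc(Br)cc1F` carries a 4-bromo-2-fluorophenyl there, and in an assay on isolated protein for inhibition of histone deacetylase 8 (Homo sapiens), with a stated time of 1 h (a higher number here means a weaker inhibitor, a lower number a stronger inhibitor), compound 1 gives only a limit, > 50000 nM. Compound 2 `O=C(COc1ccc2cc(/C=C3/SC(=O)NC3=O)ccc2c1)Nc1ccccn1` carries a pyridin-2-yl, and in this assay compound 2 gives only a limit, > 50000 nM. Compound 3 `COc1ccc(NC(=O)COc2ccc3cc(/C=C4/SC(=O)NC4=O)ccc3c2)cc1` carries a 4-methoxyphenyl, and in this assay compound 3 also gives only a limit, > 50000 nM. All three values sit together at the limit of > 50000 nM in this assay, at which 3 of the 3 values shown sit, so the steps a step that the two limits leave unreadable from compound 1 to compound 2, a step that the two limits leave unreadable from compound 1 to compound 3 and a step that the two limits leave unreadable from compound 2 to compound 3 can be read neither in size nor in direction. Compound 3 thus stands at the limit alongside the two others, with no measured number of its own.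

Compound 4 `Cc1cccc(NC(=O)COc2ccc3cc(/C=C4/SC(=O)NC4=O)ccc3c2)n1` differs from compound 3 by 6-methylpyridin-2-yl in place of 4-methoxyphenyl on an amide-type nitrogen. Going by the values given here, every exchange of the group on this nitrogen seen so far has left the value at the limit, and none of the measured steps offers a readable size that bears on this change. Compound 4 is therefore expected to stay at or near the limit, at an estimated 80000 nM within a range from 20000 nM to 300000 nM. The step this estimate implies is expected to be a step that the limit leaves unreadable from compound 3 to compound 4, not beyond the scatter.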

Compound 4, half-maximal inhibitory concentration: 7500 nM
The estimate for compound 4 lay 11-fold (1.03 log units) above the measured number, and the stated range ends above it.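

The group on the amide-type nitrogen can move the number in this assay off the limit after all: 6-methylpyridin-2-yl in place of 4-methoxyphenyl gives an at least 6.6-fold lower number from compound 3 to compound 4 (0.82 log units; beyond the scatter), and in place of 4-bromo-2-fluorophenyl it gives an at least 6.6-fold lower number from compound 1 to compound 4 (0.82 log units; beyond the scatter). The smallest change is methyl in place of hydrogen on an aromatic carbon, which gives an at least 6.6-fold lower number from compound 2 to compound 4 (0.82 log units; beyond the scatter), so this one methyl separates a compound with a measured number from one at the limit. Compound 4 alone has a measured number, while the other three compounds remain at a single limit: the limit of > 50000 nM in this assay, at which 3 of the 4 values shown sit.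

As far as these compounds go, the full size of these three steps stays open, and the steps among compound 1, compound 2 and compound 3 cannot be read. From the compounds shown here alone, whether an ethyl or an amine in place of this methyl would give a lower number also remains open.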